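Moving the Fluorine Around on a Triazole Sulfonamide

This account rests on a few compounds, and the source may have more. Where it says the series, first, only, none or still open, it means among the compounds named here.

Compound 1 `Cc1cccc(-n2cc(-c3cccc(NS(=O)(=O)c4c[nH]c(=O)[nH]c4=O)c3)nn2)c1`: 9100 nM
Compound 2 `O=c1[nH]cc(S(=O)(=O)Nc2cccc(-c3cn(-c4ccccc4F)nn3)c2)c(=O)[nH]1`: 16000 nM
Compound 3 `O=c1[nH]cc(S(=O)(=O)Nc2cccc(-c3cn(-c4cccc(F)c4)nn3)c2)c(=O)[nH]1`: > 20000 nM, a limit of the assay and not a number

The three measured compounds share one core and differ only in the phenyl group on the triazole nitrogen. In a functional assay on SGC-7901 cells (Homo sapiens) for antiproliferative activity, read by MTT assay, with a stated time of 24 h (on this read-out higher numbers stand for weaker inhibition and lower numbers for stronger inhibition), compound 1 gives 9100 nM. Exchanging its 3-methylphenyl for 2-fluorophenyl gave a 1.8-fold higher number from compound 1 to compound 2 (0.25 log units; within the scatter). Putting fluoro where the methyl stood gave an at least 2.1-fold higher number from compound 1 to compound 3 (0.34 log units; beyond the scatter). Compound 3 stands at the limit of > 20000 nM in this assay, at which 1 of the 3 values shown sits, so its value is known only as a limit, and the step of an at least 1.2-fold higher number from compound 2 to compound 3 (0.09 log units; that floor lies within the scatter) is known only as a floor.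

Compound 4 `O=c1[nH]cc(S(=O)(=O)Nc2cccc(-c3cn(-c4ccc(F)cc4)nn3)c2)c(=O)[nH]1` is not yet measured. It differs from compound 3 by 4-fluorophenyl in place of 3-fluorophenyl on an aromatic nitrogen. Among the measured compounds shown here, the only step that bears directly on it is the move of the fluorine between two positions of the phenyl, an at least 1.2-fold higher number from compound 2 to compound 3 (0.09 log units; that floor lies within the scatter), which shows no clear effect. For the measured compounds named here, no measured step suggests that a further move of the fluorine would change much. Compound 4 is therefore expected to sit close to compound 3, with a number no higher from compound 3 to compound 4 (the limit leaves the size open) as the expected step. The estimate for compound 4 in this assay is 20000 nM, with a range from 8000 nM to 50000 nM, and it may well again be reported only as a limit.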

Compound 4, half-maximal inhibitory concentration: > 20000 nM
Compound 4 gave a limit, no number; the forecaster's own chance of this, stated with the estimate: 55%; the middle value lies on the limit itself.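

In this assay compound 4 gives > 20000 nM, a limit of the assay and not a number, so a second placing of the fluorine on the phenyl ends at this same limit: the limit of > 20000 nM in this assay, at which 2 of the 4 values shown sit. Setting 4-fluorophenyl in place of 3-methylphenyl gives an at least 2.1-fold higher number from compound 1 to compound 4 (0.34 log units; beyond the scatter), which means that two fluorophenyl compounds, not just one, now stand apart from the methyl compound, while compound 2 goes against any general rule about fluorine, as its step from compound 1 lies within the scatter. Setting 4-fluorophenyl in place of 2-fluorophenyl gives an at least 1.2-fold higher number from compound 2 to compound 4 (0.09 log units; that floor lies within the scatter), which is only a floor, and the step between compound 3 and compound 4 cannot be read at all, so nothing here places these two fluorine positions in an order.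

Going by these compounds, the true values of compound 3 and compound 4 remain unknown, and so does the size of any real difference between them. On these data alone, it also stays open whether a different group on this phenyl, such as an amine, a carboxylic acid or a longer chain, would give a number lower than that of compound 1.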